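Trading 3-bromophenyl for 4-methoxyphenyl on the shared core

The source may hold more compounds than are shown below. What is called first, only, known or untested is meant among the compounds shown, and "the series" means these compounds.

In a functional assay on A549 cells (Homo sapiens) for antiproliferative activity, read by MTT assay, with a stated time of 72 h (on this read-out higher numbers stand for weaker inhibition and lower numbers for stronger inhibition), compound 1 `NC1=NC2(CCSCC2)N(OCCCOc2ccc(Cl)c(Cl)c2)C(N)=N1` gives 1 nM and compound 2 `NC1=NC2(CCSCC2)N(OCCCOc2cccc(Br)c2)C(N)=N1` gives 50 nM. Compound 2 therefore holds the higher of the two numbers, and so the weaker inhibition of the pair. Among the compounds with values here, the only measured step, a 50-fold higher number from compound 1 to compound 2 (1.70 log units; beyond the scatter), puts 3-bromophenyl in place of 3,4-dichlorophenyl on an oxygen on a saturated carbon, and it is large.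

Compound 3 `COc1ccc(OCCCON2C(N)=NC(N)=NC23CCSCC3)cc1` changes that same place again, with 4-methoxyphenyl in place of 3-bromophenyl on an oxygen on a saturated carbon. The step of a 50-fold higher number from compound 1 to compound 2 (1.70 log units; beyond the scatter) shows that this assay can respond strongly to a change here, but it does not involve the 4-methoxyphenyl group, so it guides the size only loosely. Compound 3 carries no halogen on this ring, unlike both measured compounds, so a further, more moderate rise in the number is expected, though the data cannot exclude little change. The expected step is a 3.0-fold higher number from compound 2 to compound 3 (0.48 log units; beyond the scatter). For compound 3 the estimated value is 150 nM, with an expected range of 30 nM to 800 nM.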

Compound 3, half-maximal inhibitory concentration: 240 nM
Estimate against measurement, compound 3: 1.6-fold (0.20 log units) below, within the range that was stated.
By their numbers in this assay, from the lowest: compound 1; then compound 2; then compound 3.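

The third compound shows that this position in this assay keeps responding beyond the first large change: a 4.8-fold higher number from compound 2 to compound 3 (0.68 log units; beyond the scatter), a modest step, with 4-methoxyphenyl in place of 3-bromophenyl on an oxygen on a saturated carbon. Taken from the most strongly inhibiting compound of the series, the same exchange of ring gives a 240-fold higher number from compound 1 to compound 3 (2.38 log units; beyond the scatter), a large step, so the three rings now spread the numbers widely on an unchanged core, and among these three compounds the only ring without a halogen gives the highest number, with no compound here going against that order. Nothing measured here speaks to what lies behind these steps.

The rings differ in more than one respect at a time, so these three compounds cannot separate the loss of halogen from the change of group and its place on the ring. Also open, on these data alone, is how this assay would answer a ring bearing an amine or a carboxylic acid, a ring with a single chlorine, or a longer chain carrying the ring on the oxygen.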